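This account rests on a few compounds, and the source may have more. Where it says the series, first, only, none or still open, it means among the compounds named here.

Measured so far in a functional assay on HT-29 cells (Homo sapiens) for cytotoxicity, read by MTT assay, with a stated time of 72 h; a higher number here means a weaker inhibitor, a lower number a stronger inhibitor:
compound 1 `CN(C)CCCNc1nc(-c2ccc(NC(=O)Nc3ccccc3F)cc2)nc2ccsc12`, 470 nM
compound 2 `CN(C)CCCNc1nc(-c2ccc(NC(=O)Nc3ccc(Cl)cc3Cl)cc2)nc2ccsc12`, 1860 nM
compound 3 `CN(C)CCCNc1nc(-c2ccc(NC(=O)Nc3ccc(Cl)cc3Cl)cc2)nc2c(Cl)c(Cl)sc12`, 1320 nM

Compound 1 gives the lowest number of the three; compound 3 stands a step beyond the scatter above it, and compound 2 further still, as shown by a 4.0-fold higher number from compound 1 to compound 2 (0.60 log units; beyond the scatter). Compound 2 and compound 3 differ in substitution on the shared core, and their values lie within the scatter of each other. Compound 4 `CN(C)CCNc1nc(-c2ccc(NC(=O)Nc3ccccc3F)cc2)nc2ccsc12` differs from compound 1 by dimethylamino in place of (dimethylamino)methyl on a saturated chain carbon, two bonds along the chain from a nitrogen on an aromatic ring. Among the compounds with values here, the one measured step exchanges the aryl group on the amide-type nitrogen and does not touch the chain, so nothing measured bears on this change. No step beyond the scatter is expected in this assay, the estimated step being a 1.3-fold higher number from compound 1 to compound 4 (0.11 log units; within the scatter). Compound 4 is expected at 600 nM, within 200 nM to 1800 nM.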

Compound 4, half-maximal inhibitory concentration: 510 nM
Compound 4: the middle estimate sits 1.2-fold (0.07 log units) above what was measured, and the stated range covers the measured number.
By their numbers in this assay, from the lowest: compounds 1 and 4 (each within the scatter of the next); then compounds 3 and 2 (each within the scatter of the next).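

In this assay the chain tolerates dimethylamino in place of (dimethylamino)methyl on this saturated chain carbon, with a 1.1-fold higher number from compound 1 to compound 4 (0.04 log units; within the scatter) leaving compound 1 and compound 4 level. Within the data shown here, the earlier compounds varied only the aryl group and the substitution on the shared core, so this is the first reading on the chain itself. No evidence at hand bears on this result.

Still open, going by these compounds, is whether a longer chain, a morpholine or a primary amine at the chain end would hold this level. Also open, on these data alone, is whether the shorter chain behaves alike with the 2,4-dichlorophenyl group.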